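A few compounds are considered here, and "the series" means these few. Any claim that something is new, unique, unknown or untested is made for them only; others in the source may bear on it.

Working notes on the series.

Three members of the series have been measured in a functional assay on PC-3 cells (Homo sapiens) for inhibition, read by MTT assay, with a stated time of 72 h; a higher number here means a weaker inhibitor, a lower number a stronger inhibitor. Compound 1 `CC(C)(C)OC(=O)N1CCN(C(=S)SCc2cn(Cc3ccc(Cl)cc3)nn2)CC1` carries a tert-butoxycarbonyl on the ring nitrogen; in this assay compound 1 reaches only the limit > 128000 nM. Compound 3 `COc1cc(Cn2cc(CSC(=S)N3CCN(C(=O)OC(C)(C)C)CC3)nn2)cc(OC)c1OC` is the other protected member, and in this assay compound 3 likewise sits at the limit > 128000 nM. Its deprotected partner, compound 2 `COc1cc(Cn2cc(CSC(=S)N3CCNCC3)nn2)cc(OC)c1OC`, also gives only the limit > 128000 nM in this assay. The change from compound 3 to compound 2 is hydrogen in place of tert-butoxycarbonyl on an amine nitrogen in a ring, and the step that the two limits leave unreadable from compound 3 to compound 2 is left unreadable because of the limit of > 128000 nM in this assay, at which 3 of the 3 values shown sit.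

Compound 4 `S=C(SCc1cn(Cc2ccc(Cl)cc2)nn1)N1CCNCC1`, not yet measured, arises from compound 1 by the same change, (hydrogen in place of tert-butoxycarbonyl on an amine nitrogen in a ring). How the core of compound 1 differs from that of compound 3 is not broken down here. Among the compounds with values here, since the only measured instance of this change, from compound 3 to compound 2, leaves both partners at the limit, an unreadable step of similar kind is expected from compound 1 to compound 4, a step that the limit leaves unreadable from compound 1 to compound 4. Compound 4 is estimated at 200000 nM in this assay, within 100000 nM to 1000000 nM, most likely reported as a limit again.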

Compound 4, half-maximal inhibitory concentration: > 128000 nM
Compound 4 ended at the assay's limit; the forecaster's own chance of this, stated with the estimate: 85%; the middle value does not contradict the limit.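

In this assay, no step can be read between compound 1 and compound 4, since both stand at a limit of the assay: the limit of > 128000 nM in this assay, at which 4 of the 4 values shown sit.

The compounds shown leave open whether hydrogen in place of tert-butoxycarbonyl alters inhibition in any series member giving a readable value.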